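The compounds below may be only part of what the source reports. "The series", "measured", "known", "first", "only" and "open" are said of these compounds alone.

Measured so far:

compound 1, `CCCn1cnc2c(N)nc(NCc3ccccc3)nc21`: in a functional assay on CHO cells for antagonist activity at adenosine receptor A2b (Homo sapiens) (a higher number here means a weaker inhibitor, a lower number a stronger inhibitor), compound 1 gives > 30000 nM, which is a limit of the assay and not a number.
compound 2, `CCCn1c(Br)nc2c(N)nc(NCc3ccccc3)nc21`: in this assay compound 2 gives 1740 nM.
compound 3, `CCCn1c(Br)nc2c(N)nc(NCCCc3ccccc3)nc21`: in this assay compound 3 gives 6300 nM.

Compound 2 stands lowest of the two numbers; its nearest neighbour is compound 3, with a 3.6-fold higher number from compound 2 to compound 3 (0.56 log units; beyond the scatter). Compound 1 sits at the limit of > 30000 nM in this assay, at which 1 of the 3 values shown sits. The step from that limit to compound 2 is an at least 17-fold lower number from compound 1 to compound 2 (1.23 log units; beyond the scatter).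

Compound 4, `CCCn1c(-c2ccco2)nc2c(N)nc(NCc3ccccc3)nc21`, differs from compound 2 by furan-2-yl in place of bromo on an aromatic carbon. Among the compounds with values here, the one measured step at this aromatic carbon is an at least 17-fold lower number from compound 1 to compound 2 (1.23 log units; beyond the scatter), which shows that filling the position with bromo moved the number strongly downward. Within the data shown here, no measured compound carries an aromatic ring there, so how furan-2-yl compares with bromo is open. On that footing a change near the scatter, with a slight lean to a lower number, is expected for compound 4: a 1.7-fold lower number from compound 2 to compound 4 (0.24 log units; within the scatter). The estimate for compound 4 in this assay is 1000 nM, with a range from 200 nM to 5000 nM.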

Compound 4, inhibition constant: 4610 nM
For compound 4 the middle estimate is 4.6-fold (0.66 log units) below the measured one; measured number inside the range.
By their numbers in this assay, from the lowest: compound 2; then compounds 4 and 3 (each within the scatter of the next). At a limit, above all of these: compound 1.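

In this assay, furan-2-yl, with 5 heavy atoms against the single heavy atom of bromo, keeps only part of the gain seen with bromo on this aromatic carbon: a 2.6-fold higher number from compound 2 to compound 4 (0.42 log units; beyond the scatter). An aromatic ring at this position still gives a lower number than hydrogen: an at least 6.5-fold lower number from compound 1 to compound 4 (0.81 log units; beyond the scatter). The size of that second step has an open end, as the value of compound 1 is a limit and not a number: the limit of > 30000 nM in this assay, at which 1 of the 4 values shown sits.

Still open, as far as these compounds go, is whether an amine, a carboxylic acid or another halogen such as chloro or iodo on this carbon would sit nearer to bromo or to furan-2-yl. Also open, from the compounds shown here alone, is whether bromo keeps its lead over furan-2-yl when the longer chain of compound 3 replaces the benzyl group of compound 2.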